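The source may hold more compounds than are shown below. What is called first, only, known or untested is meant among the compounds shown, and "the series" means these compounds.

Measured compounds:
compound 1 `Nc1nc(-c2cc(N3C[C@H](O)[C@@H](O)C3)ccc2O)cc(C2CCCC2)n1` — 900 nM
compound 2 `Nc1nc(NC2CCCCC2)cc(-c2cc(N3C[C@H](O)[C@@H](O)C3)ccc2O)n1` — 2000 nM
compound 3 `Cc1cc(-c2cc(N3C[C@H](O)[C@@H](O)C3)ccc2O)nc(N)n1` — 900 nM

In a functional assay on EJ cells (Homo sapiens) for cytotoxicity, with a stated time of 48 h (a higher number here means a weaker inhibitor of growth, a lower number a stronger inhibitor of growth), compound 1 stands level with compound 3, the two together giving the lowest numbers of the three, while compound 2 sits higher by a 2.2-fold higher number from compound 1 to compound 2 (0.35 log units; beyond the scatter). Compound 4 `Nc1nc(-c2cc(N3C[C@H](O)[C@@H](O)C3)ccc2O)cc(C2CCCCC2)n1` differs from compound 1 by cyclohexyl in place of cyclopentyl on an aromatic carbon. Among the measured compounds shown here, two measured steps touch this same position: no change at the digits printed from compound 1 to compound 3 (within the scatter), and a 2.2-fold higher number from compound 1 to compound 2 (0.35 log units; beyond the scatter). Swapping the cyclopentyl for a methyl thus costs nothing, and only the cyclohexylamino brings a modest rise. A plain cyclohexyl is the nearer relative of the cyclopentyl, so compound 4 is expected to show at most a small change, with a 1.1-fold higher number from compound 1 to compound 4 (0.05 log units; within the scatter) as the estimate. Compound 4 is therefore estimated at 1000 nM, within 500 nM to 2200 nM.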

Compound 4, concentration for 50% growth inhibition: 1200 nM
The estimate for compound 4 lay 1.2-fold (0.08 log units) below the measured number; low and high end bracket the measured number.
By their numbers in this assay, from the lowest: compounds 1, 3, 4 and 2 (each within the scatter of the next, the first and the last beyond it).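

In this assay, cyclohexyl at this aromatic carbon does not separate from the smaller groups, with a 1.3-fold higher number from compound 1 to compound 4 (0.12 log units; within the scatter) and a 1.3-fold higher number from compound 3 to compound 4 (0.12 log units; within the scatter) as the two steps. Compound 2 had stood apart from compound 1 and compound 3, but against the plain cyclohexyl the cyclohexylamino group gives a 1.7-fold lower number from compound 2 to compound 4 (0.22 log units; within the scatter) and no more. The added amine nitrogen therefore cannot be told apart from the plain ring in this comparison. From the compounds shown here alone, it remains open whether a phenyl or a carboxylic acid at this carbon would move the number beyond the scatter. Nothing on hand offers a measured explanation for these numbers.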